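Swapping an Oxadiazole for an Imidazole on the Amine

The source may hold more compounds than are shown below. What is called first, only, known or untested is meant among the compounds shown, and "the series" means these compounds.

In a functional assay on CHO cells for antagonist activity at corticotropin-releasing factor receptor 1 (Homo sapiens), read by cAMP accumulation (on this read-out lower numbers stand for stronger inhibition and higher numbers for weaker inhibition), compound 1 `CCCCN(CC)c1nc(C)nc2c1c(C)nn2-c1c(C)cc(C)cc1C` gives 9 nM, compound 2 `CCCN(CC(=O)N(C)C)c1nc(C)nc2c1c(C)nn2-c1ccc(OC)cc1C` gives 1410 nM, and compound 3 `CCCNCc1noc(Nc2nc(C)nc3c2c(C)nn3-c2ccc(OC)cc2C)n1` gives 84 nM. Compound 3 therefore sits second highest of the three numbers: compound 1 stands clearly lower and compound 2 clearly higher, and both gaps lie beyond the usual scatter of this assay.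

Compound 4 `CCCNCc1nccn1Nc1nc(C)nc2c1c(C)nn2-c1ccc(OC)cc1C` keeps the whole of compound 3 except one change: 2-((propylamino)methyl)-1H-imidazol-1-yl in place of 3-((propylamino)methyl)-1,2,4-oxadiazol-5-yl on a nitrogen on an aromatic ring. Among the compounds with values here, no pair of already measured compounds differs in exactly this way, so there is no directly comparable step to lean on. The amine chain and its attachment to the shared core are kept, and only the five-membered ring between them is exchanged, so the step of a 1.8-fold higher number from compound 3 to compound 4 (0.25 log units; within the scatter) is expected to be modest, leaning slightly towards a weaker inhibition, and it could well stay within the scatter. Compound 4 is accordingly estimated at about 150 nM, with a plausible range from 30 nM to 700 nM.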

Compound 4, inhibition constant: 400 nM
The estimate for compound 4 lay 2.7-fold (0.43 log units) below the measured number; the measured number falls inside the stated range.
By their numbers in this assay, from the lowest: compound 1; then compound 3; then compound 4; then compound 2.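

In this assay, the five-membered ring on this nitrogen clearly matters: with the amine chain and the shared core unchanged, exchanging 3-((propylamino)methyl)-1,2,4-oxadiazol-5-yl for 2-((propylamino)methyl)-1H-imidazol-1-yl gives a 4.8-fold higher number from compound 3 to compound 4 (0.68 log units; beyond the scatter). The change looks small on paper, since both groups have the same number of heavy atoms and the entering group simply has a carbon in place of the oxygen, yet inhibition still weakens. Nothing measured here explains this loss.

This single pair supports no general rule about five-membered rings at this position. As far as these compounds go, it remains open whether a 1,2,4-triazole ring would match the oxadiazole or the imidazole, and whether a longer chain, such as butyl in place of propyl on the amine, would change the outcome.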